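A few compounds are considered here, and "the series" means these few. Any claim that something is new, unique, unknown or untested is made for them only; others in the source may bear on it.

Measured in a functional assay (blood) for inhibition, with Homo sapiens as the target; on this read-out higher numbers stand for weaker inhibition and lower numbers for stronger inhibition:
- compound 1 `CCCC(Oc1ccc2c(c1)c(SC(C)(C)C)c(CC(C)(C)C(=O)O)n2Cc1ccc(Cl)cc1)c1ccc2ccccc2n1`: > 3000 nM (a limit of the assay, not a number)
- compound 2 `CC(C)(C)Sc1c(CC(C)(C)C(=O)O)n(Cc2ccc(Cl)cc2)c2ccc(OCc3ccc4cc(F)ccc4n3)cc12`: 880 nM
- compound 3 `CC(C)(C)Sc1c(CC(C)(C)C(=O)O)n(Cc2ccc(Cl)cc2)c2ccc(OCc3nc4ccccc4s3)cc12`: 260 nM

Only compound 2 and compound 3 have true numbers, and compound 3 has the lower of the two, at 260 nM. The next compound, compound 4 `C[C@@H](COc1ccc2c(c1)c(SC(C)(C)C)c(CC(C)(C)C(=O)O)n2Cc1ccc(Cl)cc1)c1ccccn1`, has not yet been measured. It keeps the shared core and differs from compound 3 in one place: 1-(pyridin-2-yl)ethyl in place of 1,3-benzothiazol-2-yl on a saturated chain carbon bound to an oxygen on an aromatic ring. In words, it has 1-(pyridin-2-yl)ethyl in place of 1,3-benzothiazol-2-yl on a saturated chain carbon bound to an oxygen on an aromatic ring.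

One measured step changes a group at this place: a 3.4-fold lower number from compound 2 to compound 3 (0.53 log units; beyond the scatter). That modest step shows that the read-out responds to this group, but the new group is quite different from both earlier ones, so it offers only a rough guide. Compound 3 already holds the lowest number, so a modest rise is expected, meaning weaker inhibition. The expected change is a 3.1-fold higher number from compound 3 to compound 4 (0.49 log units; beyond the scatter). For compound 4, the estimate is 800 nM, with an expected range of 250 nM to 2500 nM.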

Compound 4, half-maximal inhibitory concentration: 280 nM
Compound 4: middle estimate off by 2.9-fold (0.46 log units), on the high side; the measured number falls inside the stated range.
By their numbers in this assay, from the lowest: compounds 3 and 4 (each within the scatter of the next); then compound 2. At a limit, above all of these: compound 1.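

In this assay, putting 1-(pyridin-2-yl)ethyl in place of 1,3-benzothiazol-2-yl on a saturated chain carbon bound to an oxygen on an aromatic ring gives a 1.1-fold higher number from compound 3 to compound 4 (0.03 log units; within the scatter), so this place accepts a group with one six-membered aromatic ring and a defined stereocentre without a change that can be told from the scatter. The same group gives a 3.1-fold lower number from compound 2 to compound 4 (0.50 log units; beyond the scatter), so two quite different groups now stand apart from 6-fluoroquinolin-2-yl by a modest margin. Nothing measured here explains why these two groups read alike.

On these data alone, it remains open whether the mirror-image form of the 1-(pyridin-2-yl)ethyl group would give the same reading. Also open, as far as these compounds go, is whether a plain phenyl ring, or an amine in place of the aromatic ring, would hold up at this place.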